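The compounds below may be only part of what the source reports. "The series", "measured", "known", "first", "only" and "open" are said of these compounds alone.

Going by the values given here, compound 2 `Cc1ccccc1N1CCC(C(=O)Nc2ccc3c(c2)NC(=O)CO3)CC1` is one of only two compounds measured so far. In an assay on HEK293 cells for displacement of a labelled ligand from transient receptor potential cation channel subfamily V member 1 (Homo sapiens) (a lower number here means a stronger inhibitor, a higher number a weaker inhibitor), compound 2 gives 61 nM. The other compound is compound 1 `O=C1COc2ccc(NC(=O)C3CCN(c4ccccc4Br)CC3)cc2N1`, which in this assay gives 71 nM; the step of a 1.2-fold lower number from compound 1 to compound 2 (0.07 log units; within the scatter) is too small to separate the two, so neither can be called the stronger binder.

Compound 3 `O=C1COc2ccc(NC(=O)C3CCN(c4cccc(Cl)c4)CC3)cc2N1` differs from compound 2 by 3-chlorophenyl in place of 2-methylphenyl on an amine nitrogen in a ring. Among the compounds with values here, only one measured step bears on this: it is the step of a 1.2-fold lower number from compound 1 to compound 2 (0.07 log units; within the scatter), which also exchanged the group on the phenyl that sits on the amine nitrogen in the ring and left the number essentially unchanged. Within the data shown here, no measured step moves the group from the 2-position of that phenyl to the 3-position, and none puts chlorine there, so the effect of the new arrangement is unknown. The step from compound 2 to compound 3 is therefore expected to be small, with no direction beyond the scatter, as a 1.2-fold higher number from compound 2 to compound 3 (0.09 log units; within the scatter). For compound 3 the estimate in this assay is 75 nM, with a likely range from 25 nM to 220 nM.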

Compound 3, inhibition constant: 97 nM
Estimate against measurement, compound 3: 1.3-fold (0.11 log units) below; low and high end bracket the measured number.
By their numbers in this assay, from the lowest: compounds 2, 1 and 3 (each within the scatter of the next).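

In this assay, the swap on the amine nitrogen gives a 1.6-fold higher number from compound 2 to compound 3 (0.20 log units; within the scatter) and a 1.4-fold higher number from compound 1 to compound 3 (0.14 log units; within the scatter), and both steps stay within the scatter. Going by these compounds alone, until now, only phenyl groups named with a 2-position had been compared, 2-bromophenyl and 2-methylphenyl, so this is the first sign that 3-chlorophenyl, which differs in both the atom and the numbered position, can stand on that nitrogen without a readable change in the number. No supporting data are available to explain this result or tie it to any property of these groups.

Each step here changes the atom and its position on the phenyl together, so a 3-methylphenyl or a 2-chlorophenyl would be needed to show each change alone. From the compounds shown here alone, it also remains open whether the number would stay within the scatter with a much different group on that phenyl, such as a carboxylic acid or an amine, or with a plain phenyl carrying no added group.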